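Swapping trifluoromethyl for trifluoromethoxy at one ring position

The compounds below may be only part of what the source reports. "The series", "measured", "known", "first", "only" and "open" are said of these compounds alone.

Of the compounds shown here, three have been measured so far in a functional assay on A2780 cells (Homo sapiens) for inhibition, read by sulforhodamine B assay; on this read-out lower numbers stand for stronger inhibition of growth and higher numbers for weaker inhibition of growth. Compound 1 `FC(F)(F)Oc1ccc(-c2ccc(-c3ccc(-c4nc5ccccc5[nH]4)cc3)cc2)cc1` gives 100000 nM, and compound 2 `Oc1cccc2[nH]c(-c3ccc(-c4ccc(-c5ccc(F)cc5)cc4)cc3)nc12` gives 41200 nM. Compound 3 `Oc1cccc2[nH]c(-c3ccc(-c4ccc(-c5ccc(C(F)(F)F)cc5)cc4)cc3)nc12` gives 6100 nM, the lowest of the three numbers, and its gaps to both others lie beyond the scatter.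

The next compound, still unmeasured, is compound 4 `Oc1cccc2[nH]c(-c3ccc(-c4ccc(-c5ccc(OC(F)(F)F)cc5)cc4)cc3)nc12`. It differs from compound 3 in one place: trifluoromethoxy in place of trifluoromethyl on an aromatic carbon. Trifluoromethoxy stands in place of trifluoromethyl on an aromatic carbon of a six-membered aromatic ring of carbon only, para to a large group.

Among the compounds with values here, one measured step touches this same place: a 6.8-fold lower number from compound 2 to compound 3 (0.83 log units; beyond the scatter), a modest change beyond the scatter, made when trifluoromethyl replaced fluoro. Within the data shown here, no single change links compound 1 to the others, so it offers no step here. Among the measured compounds shown here, no measured pair makes the swap itself, and that lone step gives it no direction. Any shift is therefore expected to stay smaller than that step, probably within the scatter. The expected result in this assay is a 1.1-fold lower number from compound 3 to compound 4 (0.04 log units; within the scatter), which would be no real change. For compound 4 the estimated value is 5500 nM, with an expected range from 1800 nM to 18000 nM.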

Compound 4, concentration for 50% growth inhibition: 2900 nM
Estimate against measurement, compound 4: 1.9-fold (0.28 log units) above; measured number inside the range.
By their numbers in this assay, from the lowest: compound 4; then compound 3; then compound 2; then compound 1.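

In this assay, within the data shown here, the swap itself now has a measured size, a 2.1-fold lower number from compound 3 to compound 4 (0.32 log units; beyond the scatter) and this modest shift shows that the position can tell trifluoromethoxy from trifluoromethyl, which the earlier compounds could not show. Among the three groups seen at this place, the numbers run from lowest to highest as trifluoromethoxy, trifluoromethyl and fluoro, and replacing fluoro directly gives a 14-fold lower number from compound 2 to compound 4 (1.15 log units; beyond the scatter) as a large change that exceeds the modest step from fluoro to trifluoromethyl. A second place also comes into view with trifluoromethoxy held constant, since hydroxy in place of hydrogen on an aromatic carbon of the shared core gives a 34-fold lower number from compound 1 to compound 4 (1.54 log units; beyond the scatter) as another large change.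

On these data alone, how an amine, a carboxylic acid or a longer chain would read at the position now holding trifluoromethoxy remains open, and so does whether the order of the three groups would hold on a core without the hydroxy. Nothing available here accounts for the size or direction of these shifts.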